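The source may hold more compounds than are shown below. What is called first, only, known or untested is meant among the compounds shown, and "the series" means these compounds.

Compound 1 `C=CC1=C(C(=O)NCc2ccccc2)C(c2ccc(OC)cc2)OC1` — in a functional assay on A549 cells (Homo sapiens) for cytotoxicity, read by MTT assay, with a stated time of 24 h (a higher number here means a weaker inhibitor, a lower number a stronger inhibitor), compound 1 gives > 100000 nM, which is a limit of the assay.
Compound 2 `C=CC1=C(C(=O)O)C(c2ccc(OC)cc2)OC1` — in this assay compound 2 gives > 100000 nM, likewise a limit.

Going by the values given here, the only step between measured compounds, a step that the two limits leave unreadable from compound 1 to compound 2, puts hydroxy in place of benzylamino on a carbonyl carbon; its size stays unreadable because the limit of > 100000 nM in this assay, at which 2 of the 2 values shown sit, covers both ends of it. Compound 2 therefore stands at a limit only, with no number of its own.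

Compound 3 `C=CC1=C(C(=O)O)C(c2ccc(OC)c(OC)c2)OC1` differs from compound 2 by methoxy in place of hydrogen on an aromatic carbon. Among the compounds with values here, no measured step adds a methoxy, and the one step known is unreadable, so nothing indicates a change beyond the scatter in this assay. Compound 3 is accordingly expected to stay near the limit, with an estimated step that the limit leaves unreadable from compound 2 to compound 3. The estimate for compound 3 is 150000 nM, within 50000 nM to 500000 nM.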

Compound 3, half-maximal inhibitory concentration: > 100000 nM
Compound 3: only a limit was reported; the forecaster's own chance of this, stated with the estimate: 80%; the middle value is on the limit's open side.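

In this assay, going by these compounds alone, compound 3 gives > 100000 nM as a limit of the assay, so no step between compound 2 and compound 3 can be read: the limit of > 100000 nM in this assay, at which 3 of the 3 values shown sit.

The compounds shown leave open how far any of the three lies beyond that limit, and whether the added methoxy changes anything.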